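The source may hold more compounds than are shown below. What is called first, only, known or untested is meant among the compounds shown, and "the series" means these compounds.

Compound 1 `COc1ccc2nc(C)cc(OCC(=O)Nc3cc(C)cc(C)c3)c2c1` stands second highest of the three numbers measured in a physicochemical assay for lipophilicity, read by HPLC, in phosphate buffer, measured as chromatographic lipophilicity, at pH 7.4 (a higher number here means a more lipophilic compound, a lower number a more polar compound), where compound 1 gives 5.64. Its nearest neighbour is compound 2 `Cc1cc(C)cc(NC(=O)COc2cc(C)nc3ccccc23)c1`, which in this assay gives 5.39; the step of a number 0.25 log units lower from compound 1 to compound 2 (within the scatter) is within the scatter. Furthest from it is compound 3 `Cc1cc(C)cc(NC(=O)COc2cc(C)nc3ccc(C(F)(F)F)cc23)c1`, which gives 6.67 in this assay, a step of a number 1.03 log units higher from compound 1 to compound 3 (beyond the scatter), beyond the scatter. Between the other pair the step is a number 1.28 log units higher from compound 2 to compound 3 (beyond the scatter), also large.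

Compound 4 `Cc1cc(C)cc(NC(=O)COc2cc(C)nc3ccc(OCc4ccccc4)cc23)c1` has not yet been measured. It differs from compound 1 by phenyl in place of hydrogen on a saturated chain carbon bound to an oxygen on an aromatic ring. Going by the values given here, none of the measured steps makes this same change: each of them swaps the group on an aromatic carbon of the shared core, whereas here the methoxy of compound 1 is kept and extended to benzyloxy. Among the compounds with values here, the only guide to how far one substitution on this core can move the number is the step from compound 1 to compound 3, at a number 1.03 log units higher from compound 1 to compound 3 (beyond the scatter). Compound 4 is therefore expected to sit higher than compound 1, by an estimated step of a number 1.56 log units higher from compound 1 to compound 4 (beyond the scatter), clearly beyond the scatter. The estimate for compound 4 in this assay is 7.2, expected to fall between 6.6 and 7.8.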

Compound 4, distribution coefficient: 7.03
Estimate against measurement, compound 4: 0.17 log units above, within the range that was stated.
By their numbers in this assay, from the lowest: compounds 2 and 1 (each within the scatter of the next); then compound 3; then compound 4.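

Going by these compounds alone, compound 4 shows that the group on this aromatic carbon need not be swapped to shift the reading in this assay: keeping the methoxy oxygen and extending methoxy to benzyloxy gives a number 1.39 log units higher from compound 1 to compound 4 (beyond the scatter) and so adds a large step, which the earlier compounds, all swaps on the aromatic carbon, could not show. Benzyloxy also stands apart from the other groups at this place, with a number 0.36 log units higher from compound 3 to compound 4 (beyond the scatter) and a number 1.64 log units higher from compound 2 to compound 4 (beyond the scatter), so among the four compounds it gives the highest number, its steps to all three others being beyond the scatter. Nothing among the data shown gives a reason for the size of these steps.

Still open, on these data alone, is whether a longer chain carrying the phenyl would move the number further than benzyloxy does, or whether a cyclohexyl in place of the phenyl would give a step of similar size. As far as these compounds go, it is also open how the number would respond to an amine or a carboxylic acid on the phenyl ring of compound 4 .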